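This account rests on a few compounds, and the source may have more. Where it says the series, first, only, none or still open, it means among the compounds named here.

Measured so far in a functional assay on K562 cells (Homo sapiens) for cytotoxicity, read by MTT assay, with a stated time of 5 days (on this read-out higher numbers stand for weaker inhibition and lower numbers for stronger inhibition), each value a limit of the assay and not a number:

- compound 1 `COc1ccc(-c2cnnn2Cc2cc(OC)c(OC)c(OC)c2)cc1Br`: > 10000 nM
- compound 2 `COc1ccc(-c2cn(-c3cc(OC)c(OC)c(OC)c3)nn2)cc1`: > 10000 nM
- compound 3 `COc1ccc(-c2cn(-c3cc(OC)c(OC)c(OC)c3)nn2)cc1Br`: > 10000 nM

Compound 3 gives no number and sits at the limit of > 10000 nM in this assay, at which 3 of the 3 values shown sit. It therefore cannot be ordered against the other two compounds.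

Compound 4 `COc1ccc(-c2cn(-c3cc(OC)c(OC)c(OC)c3)nn2)cc1O` differs from compound 3 in one place: hydroxy in place of bromo on an aromatic carbon. The change is hydroxy in place of bromo on an aromatic carbon, ortho to a methoxy group and meta to a large group.

For the measured compounds named here, the one measured step that bears on this change is a step that the two limits leave unreadable from compound 2 to compound 3. It involves bromo in place of hydrogen and offers no size to carry over. Going by the values given here, no measured compound carries the hydroxy group, so the data set no firm size for the change in this assay.

The expectation starts from compound 3, whose limit is > 10000 nM. Any readable movement is expected towards stronger inhibition, though compound 4 may well remain at the limit. The expected size is an at least 2.0-fold lower number from compound 3 to compound 4 (0.30 log units; that floor lies within the scatter), and this is an estimate only. For compound 4 the estimated value is 5000 nM, with an expected range of 500 nM to 20000 nM.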

Compound 4, half-maximal inhibitory concentration: > 10000 nM
Compound 4: no number, only a limit (the forecaster's own chance of this, stated with the estimate: 55%); middle value at least 2.0-fold (0.30 log units) away from the limit.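

In this assay compound 4 gives a limit of the assay and not a number (> 10000 nM). The steps to compound 4 from compound 3 and from compound 2 cannot be read: the limit of > 10000 nM in this assay, at which 4 of the 4 values shown sit. In this assay the compounds shown leave open whether hydrogen, bromo or hydroxy on this aromatic carbon makes any difference.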